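This account rests on a few compounds, and the source may have more. Where it says the series, first, only, none or still open, it means among the compounds named here.

Of the compounds shown here, three that share one core have so far been measured in a functional assay for inhibition of nuclear factor NF-kappa-B complex (Homo sapiens); on this read-out lower numbers stand for stronger inhibition and higher numbers for weaker inhibition. Compound 1 `COc1ccc2c(c1)OC(c1cc(OC)c(OC)c(OC)c1)C(C(=O)N(C)OC)=C2` gives 11700 nM, compound 2 `COc1ccc2c(c1)OC(c1cc(OC)c(OC)c(OC)c1)C(C(=O)OCCc1ccccc1)=C2` gives 16200 nM, and compound 3 `CCOC(=O)C1=Cc2ccc(OC)cc2OC1c1cc(OC)c(OC)c(OC)c1` gives 25000 nM. Compound 2 lies close to both of the others: a 1.4-fold higher number from compound 1 to compound 2 (0.14 log units; within the scatter) and a 1.5-fold higher number from compound 2 to compound 3 (0.19 log units; within the scatter). For the measured compounds named here, only the step that skips compound 2 reaches beyond the scatter, and even that is modest: a 2.1-fold higher number from compound 1 to compound 3 (0.33 log units; beyond the scatter). Compound 4 `COc1ccc2c(c1)OC(c1cc(OC)c(OC)c(OC)c1)C(C(C)=O)=C2` has not yet been measured; it differs from compound 2 by methyl in place of phenethyloxy on a carbonyl carbon. Every measured step changes the group on that same carbonyl carbon and stays small, so the step of a 1.1-fold lower number from compound 2 to compound 4 (0.03 log units; within the scatter) is expected to be small too, with no firm direction. Compound 4 is therefore estimated at 15000 nM, within a range from 6000 nM to 40000 nM.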

Compound 4, half-maximal inhibitory concentration: 14100 nM
Estimate against measurement, compound 4: 1.1-fold (0.03 log units) above; low and high end bracket the measured number.
By their numbers in this assay, from the lowest: compounds 1, 4, 2 and 3 (each within the scatter of the next, the first and the last beyond it).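

Replacing phenethyloxy, with its aromatic ring, by a single methyl on this carbonyl carbon stays within the scatter in this assay (a 1.1-fold lower number from compound 2 to compound 4 (0.06 log units; within the scatter)). Methyl in place of ethoxy (a 1.8-fold lower number from compound 3 to compound 4 (0.25 log units; within the scatter)) and in place of methoxy(methyl)amino (a 1.2-fold higher number from compound 1 to compound 4 (0.08 log units; within the scatter)) also stays within it, so among these compounds neither the aromatic ring nor an oxygen or nitrogen attached to the carbonyl carbon is needed to keep the number in this range. Nothing available explains why these groups read so alike.

The compounds shown leave open whether a carboxylic acid or a chain ending in an amine on this carbonyl carbon would move the number beyond the scatter. They also leave open how much changes elsewhere on the shared core would matter.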